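From compound 3 to compound 4

The source may report more compounds than this note shows. Statements on the series, on what has been measured and on what is new or still open speak of the compounds shown alone.

Values in an ADME assay on MT4 cells (Homo sapiens) for cytotoxicity, read by MTT assay, with a stated time of 5 days; a higher number here means that more compound is tolerated, a lower number that less compound is tolerated:
Compound 1 `N#Cc1ccc(Nc2nccc(OCC(=O)Nc3ccc(F)cc3)n2)cc1`: > 344000 nM, a limit
Compound 2 `Cc1cc(OCC(=O)Nc2ccc(Br)cc2)nc(Nc2ccc(C#N)cc2)n1`: 930 nM
Compound 3 `Cc1cnc(Nc2ccc(C#N)cc2)nc1OCC(=O)Nc1ccc(F)cc1`: > 331000 nM, a limit

Compound 3 has no number in this assay, only the limit > 331000 nM. Compound 4 `Cc1cnc(Nc2ccc(C#N)cc2)nc1OCC(=O)Nc1cccc(Cl)c1` carries 3-chlorophenyl in place of 4-fluorophenyl on an amide-type nitrogen. Going by the values given here, the one measured step, a step that the two limits leave unreadable from compound 1 to compound 3, is methyl in place of hydrogen on an aromatic carbon, and it offers no size to carry over. Among the compounds with values here, compound 2 alone has a number, 930 nM, and no single-change step links it to the others. That value still leaves room for a modest downward move in this assay, which is only an expectation. The expected step is an at least 3.3-fold lower number from compound 3 to compound 4 (0.51 log units; beyond the scatter). Compound 4 is estimated at 100000 nM, within 8000 nM to 320000 nM.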

Compound 4, half-maximal cytotoxic concentration: 144000 nM
For compound 4 the middle estimate is 1.4-fold (0.16 log units) below the measured one, within the range that was stated.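

In this assay, 3-chlorophenyl in place of 4-fluorophenyl on an amide-type nitrogen gives an at least 2.2-fold lower number from compound 3 to compound 4 (0.36 log units; beyond the scatter). Going by these compounds alone, this is the first readable step and shows that the aryl group on this nitrogen can move the number, whereas the step from compound 1 to compound 3 cannot be read. Going by these compounds, its full size stays unknown because compound 3 has only a limit: the limit of > 331000 nM in this assay, at which 1 of the 4 values shown sits.

Open, on these data alone, is whether the chlorine itself or the loss of 4-fluorophenyl carries this step. Also open, as far as these compounds go, is what a benzyl group or a longer alkyl chain on this nitrogen would give.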